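The compounds below may be only part of what the source reports. "The series", "measured", "known", "first", "only" and "open" are said of these compounds alone.

The three measured compounds in a functional assay on HL-60 cells (Homo sapiens) for antiproliferative activity, read by MTT assay, with a stated time of 72 h (on this read-out higher numbers stand for weaker inhibition and lower numbers for stronger inhibition), are:

compound 1 `C=C(Br)C(=O)Nc1ccc2c(c1)/C(=C\c1cccs1)C(=O)N2` — 15 nM
compound 2 `C#CC(=O)Nc1ccc2c(c1)/C(=C/c1ccc[nH]1)C(=O)N2` — 5800 nM
compound 3 `C=C(Br)C(=O)Nc1ccc2c(c1)CC(=O)N2` — 350 nM

Of these three, compound 1 has the lowest number and so the strongest inhibition in this assay, and its distance to each of the other two lies beyond the usual scatter. Compound 3, which keeps the bromoacrylamide but carries no arylidene group on the shared core, is the nearer of the two, while compound 2, with a propiolamide and a pyrrole in place of the thiophene, stands furthest away. Going by the values given here, no single-change step between any pair of these measured compounds is available, so the contribution of each part can only be read from what the values show.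

Compound 4 `C=C(Br)C(=O)Nc1ccc2c(c1)/C(=C\c1sccc1C)C(=O)N2` is the unmeasured analogue of compound 1. It differs in one place only: methyl in place of hydrogen on an aromatic carbon. Among the compounds with values here, no measured pair in this set isolates such a change, so no step can be quoted for it. The account expects the step of a 1.3-fold higher number from compound 1 to compound 4 (0.12 log units; within the scatter) to be small and in no clear direction, staying within the scatter of repeated measurements. On that basis compound 4 is estimated at 20 nM in this assay, with a range from 6 nM to 60 nM.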

Compound 4, half-maximal inhibitory concentration: 39 nM
Beside the measured number, compound 4's estimate is 2.0-fold (0.29 log units) below it; measured number inside the range.
By their numbers in this assay, from the lowest: compound 1; then compound 4; then compound 3; then compound 2.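

In this assay, going by these compounds alone, the step (a 2.6-fold higher number from compound 1 to compound 4 (0.41 log units; beyond the scatter)) is the first single change that can be read in this set, and it shows that a methyl group on the thiophene, at the carbon next to the ring atom that bears a large group and two ring bonds from the ring sulfur, does not leave the number unchanged. The step is modest, and adding this one carbon weakens inhibition without abolishing it: compound 4 still reads 39 nM and keeps the bromoacrylamide and the arylidene link of compound 1 intact. No measurement shown here explains why this methyl group has this effect.

Whether the change belongs to methyl in particular or would follow any group at this carbon remains open, as the compounds shown hold no ethyl chain, methoxy group, chlorine atom or amine there. Also open, going by these compounds, is whether the same methyl group would give a step of similar size on other thiophene carbons, or on the pyrrole of compound 2 with its propiolamide.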